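The source may hold more compounds than are shown below. What is called first, only, known or untested is meant among the compounds shown, and "the series" means these compounds.

Measured in a functional assay on cells (Hepatocyte, Rattus norvegicus) for inhibition, read by scintillation counting, with a stated time of 4 h; a higher number here means a weaker inhibitor, a lower number a stronger inhibitor:
- compound 1 `O=C(O)C[C@H](O)C[C@H](O)CCn1c(-c2ccc(F)cc2)nc(C(=O)NCc2ccc(F)cc2)c1C1CC1`: 0.7 nM
- compound 2 `Cc1ccc(CNC(=O)c2nn(-c3ccc(F)cc3)c(CC[C@@H](O)C[C@@H](O)CC(=O)O)c2C(C)C)cc1`: 0.9 nM

Compound 1, at 0.7 nM, lies within the scatter of compound 2, at 0.9 nM, so the two values give no order. Among the compounds with values here, compound 1 therefore stands level with the only other measured compound, and both are in the low range of this assay.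

Compound 3 `O=C(O)C[C@H](O)C[C@H](O)CCn1c(-c2ccc(F)cc2)nc(C(=O)NCc2ccccc2)c1C1CC1` comes from compound 1 by one change: hydrogen in place of fluoro on an aromatic carbon. In words, hydrogen replaces fluoro on an aromatic carbon, turning 4-fluorobenzyl into benzyl.

Within the data shown here, no measured pair isolates this change, so its size has to be judged without a direct precedent. A step no larger than the scatter is expected, with a slight lean towards a higher number. The expected 1.4-fold higher number from compound 1 to compound 3 (0.15 log units; within the scatter) is small. For compound 3 the estimated value is 1 nM, with an expected range of 0.4 nM to 2.5 nM.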

Compound 3, half-maximal inhibitory concentration: 0.2 nM
Compound 3: middle estimate off by 5.0-fold (0.70 log units), on the high side; the measured number lies below the stated range.
By their numbers in this assay, from the lowest: compound 3; then compounds 1 and 2 (each within the scatter of the next).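

Hydrogen in place of fluoro, turning 4-fluorobenzyl into benzyl, gives a 3.5-fold lower number from compound 1 to compound 3 (0.54 log units; beyond the scatter) in this assay, the only step in the series so far that can be read. It shows that this aromatic carbon is not indifferent to what it carries, and that the fluoro is not needed for a low number here, since the plain benzyl of compound 3 is the better of the two. Nothing measured here accounts for the step.

The compounds shown leave open how a methoxy, a chloro or an amine on this aromatic carbon would read. They also leave open whether hydrogen in place of fluoro on the 4-fluorophenyl group, which compound 3 keeps, would move the number in the same direction.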